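This account rests on a few compounds, and the source may have more. Where it says the series, first, only, none or still open, it means among the compounds named here.

Measured compounds and their values:

Compound 1 `O=C1c2c[n+]([O-])c3ccccc3c2C(=O)c2c1c1ccccc1n2CCCCN1CCNCC1` gives 1240 nM in a functional assay on SH-SY5Y cells (Homo sapiens) for cytotoxicity, read by MTT assay, with a stated time of 72 h; on this read-out lower numbers stand for stronger inhibition and higher numbers for weaker inhibition.
Compound 2 `CC1(C)OC[C@@H](Cn2cc(Cn3c4c(c5ccccc53)C(=O)c3c[n+]([O-])c5ccccc5c3C4=O)nn2)O1` gives a limit of this assay, > 1000 nM.
Compound 3 `O=C1c2c[n+]([O-])c3ccccc3c2C(=O)c2c1c1ccccc1n2Cc1cn([C@@H]2O[C@H](CO)[C@@H](O)[C@H](O)[C@H]2O)nn1` gives 880 nM.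

Among the measured compounds shown here, of the two numbers in hand, the one for compound 1 is the higher, though the gap to compound 3 lies within the scatter. For the measured compounds named here, the only step between measured compounds that differ in one place is an at least 1.1-fold lower number from compound 2 to compound 3 (0.05 log units; that floor lies within the scatter), and it rests on (the limit of > 1000 nM in this assay, at which 1 of the 3 values shown sits), so it says little about any change at all and nothing about the chain carried on the aromatic nitrogen of compound 1.

Compound 4 `O=C1c2c[n+]([O-])c3ccccc3c2C(=O)c2c1c1ccccc1n2CCCN1CCC(O)CC1` has not yet been measured. It differs from compound 1 by 4-hydroxypiperidin-1-yl in place of (piperazin-1-yl)methyl on a saturated chain carbon, three bonds along the chain from an aromatic nitrogen. Going by the values given here, no measured step bears on this change; the two measured steps concern the group on the aromatic nitrogen and leave the chain end untouched. With nothing to point either way, the expectation is for no step beyond the scatter, so the estimate is a 1.0-fold lower number from compound 1 to compound 4 (0.01 log units; within the scatter). Compound 4 is therefore expected to give about 1200 nM, within a range from 500 nM to 3000 nM.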

Compound 4, half-maximal inhibitory concentration: 130 nM
Beside the measured number, compound 4's estimate is 9.2-fold (0.97 log units) above it; measured number outside the range, below it.
By their numbers in this assay, from the lowest: compound 4; then compounds 3 and 1 (each within the scatter of the next).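

In this assay, the end of the chain on the aromatic nitrogen proves to matter: 4-hydroxypiperidin-1-yl in place of (piperazin-1-yl)methyl on a saturated chain carbon, three bonds along the chain from an aromatic nitrogen, gives a 9.5-fold lower number from compound 1 to compound 4 (0.98 log units; beyond the scatter) and is the only step shown that clearly exceeds the scatter. Cut one bond further out, the same difference reads 4-(piperazin-1-yl)butyl to 3-(4-hydroxypiperidin-1-yl)propyl, so the ring and the chain length change together in this single step. Nothing in the data at hand accounts for the size of this step.

The compounds shown do not separate the two changes, which would take the 3-(piperazin-1-yl)propyl and 4-(4-hydroxypiperidin-1-yl)butyl chains. They also leave open how a chain ending in morpholine or in piperidine without the hydroxyl group would compare.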